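Methyl Added to the Shared Core: an Expected Step

The source may hold more compounds than are shown below. What is called first, only, known or untested is meant among the compounds shown, and "the series" means these compounds.

Compound 1 `N/C(=N\NC(=S)N1CCOCC1)c1ccccn1`: 680 nM
Compound 2 `N/C(=N\NC(=S)N1CCCCC1)c1ccccn1`: 680 nM
Compound 3 `Cc1cccc(/C(N)=N/NC(=S)N2CCOCC2)n1`: 14000 nM

These values come from a functional assay on A-375 cells (Homo sapiens) for cytotoxicity, read by MTT assay, with a stated time of 72 h; on this read-out higher numbers stand for weaker inhibition and lower numbers for stronger inhibition. Compound 1 and compound 2 differ only by piperidin-1-yl in place of morpholin-4-yl on a thiocarbonyl carbon, and this gives no change at the digits printed from compound 1 to compound 2 (within the scatter). Compound 3 carries one extra methyl on the ring of compound 1, namely (methyl in place of hydrogen on an aromatic carbon), and the step is a 21-fold higher number from compound 1 to compound 3 (1.31 log units; beyond the scatter), a large one.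

Compound 4 `Cc1ccnc(/C(N)=N/NC(=S)N2CCCCC2)c1` is not yet measured. It differs from compound 2 by methyl in place of hydrogen on an aromatic carbon. This is the same kind of change as that from compound 1 to compound 3, not the same: in compound 3 the methyl sits next to the ring nitrogen, while in compound 4 it sits opposite the ring nitrogen, in both cases meta to a large group. A smaller step of a 2.2-fold higher number from compound 2 to compound 4 (0.34 log units; beyond the scatter) is estimated for compound 4 because the large step of a 21-fold higher number from compound 1 to compound 3 (1.31 log units; beyond the scatter) arose with the methyl at a different place on the ring. Compound 4 is therefore expected to give 1500 nM, with a likely range from 500 nM to 6000 nM.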

Compound 4, half-maximal inhibitory concentration: 1900 nM
The estimate for compound 4 lay 1.3-fold (0.10 log units) below the measured number, and the stated range covers the measured number.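

In this assay, a methyl in place of hydrogen on the ring gives a higher number in both pairs shown, and the new step is a 2.8-fold higher number from compound 2 to compound 4 (0.45 log units; beyond the scatter), a modest one. The direction of the change carries from one core to the other in these two pairs, but its size does not: the same change on two cores in this assay, a 21-fold higher number (1.31 log units; beyond the scatter) from compound 1 to compound 3 and a 2.8-fold higher number (0.45 log units; beyond the scatter) from compound 2 to compound 4, 7.4-fold (0.87 log units) apart, beyond the scatter of two such steps These two steps differ in two things at once, the group on the thiocarbonyl carbon and the place of the methyl, which is opposite the ring nitrogen in compound 4 but not in compound 3, so the gap cannot be assigned to either difference, and two pairs give no general rule.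

The compounds shown leave open how the same methyl placement behaves with morpholin-4-yl and with piperidin-1-yl, a comparison that would separate those two differences. They also leave open whether another group opposite the ring nitrogen, such as an ethyl, a methoxy or an amine, would give a step like that of the methyl.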